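The source may hold more compounds than are shown below. What is called first, only, known or untested is meant among the compounds shown, and "the series" means these compounds.

In a functional assay on KB cells (Homo sapiens) for cytotoxicity (on this read-out higher numbers stand for an effect only at larger amounts of compound and lower numbers for an effect already at smaller amounts), compound 1 (`COC1=C(C)C(=O)/C(=C(O)/C=C/c2ccc(F)cc2)C(=O)C1(C)C`) gives 2.7 ug/mL while compound 2 (`COC1=C(C)C(=O)/C(=C(O)/C=C/c2cc(C)cc(C)c2)C(=O)C1(C)C`) gives 1.6 ug/mL and compound 3 (`COC1=C(C)C(=O)/C(=C(O)/C=C/c2c(C)cc(C)cc2C)C(=O)C1(C)C`) gives 1.84 ug/mL on the same read-out. These three numbers lie within the scatter of one another, so compound 1 stands level with the other two and not apart from them. Compound 4 (`COC1=C(C)C(=O)/C(=C(O)/C=C/c2cccs2)C(=O)C1(C)C`) has not yet been measured. Its difference from compound 1 is thiophen-2-yl in place of 4-fluorophenyl on a double-bonded chain carbon bound to a double-bonded chain carbon and it falls on a double-bonded chain carbon bound to a double-bonded chain carbon. Within the data shown here, the one measured step that bears on this is the exchange at the same place (a 1.7-fold lower number from compound 1 to compound 2 (0.23 log units; within the scatter)) and it stays within the scatter. Compound 3, which also differs at that place, shows 1.84 ug/mL and adds no larger gap. Among the measured compounds shown here, none of the measured compounds carries a five-membered aromatic ring there, however, so the data offer no direct precedent for thiophen-2-yl. No step beyond the scatter is therefore expected in this assay for this change. The estimated step runs a 1.2-fold lower number from compound 1 to compound 4 (0.09 log units; within the scatter) and would lie within the scatter. For compound 4 the expected value is 2.2 ug/mL with an estimated range from 1 ug/mL to 4.8 ug/mL on this read-out.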

Compound 4, concentration for half-maximal effect: 3.4 ug/mL
For compound 4 the middle estimate is 1.5-fold (0.19 log units) below the measured one; low and high end bracket the measured number.
By their numbers in this assay, from the lowest: compounds 2, 3, 1 and 4 (each within the scatter of the next, the first and the last beyond it).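

In this assay, thiophen-2-yl in place of 4-fluorophenyl, on a double-bonded chain carbon bound to a double-bonded chain carbon, gives a 1.3-fold higher number from compound 1 to compound 4 (0.10 log units; within the scatter), so this position now has a five-membered aromatic ring with a sulfur atom that stands level with the six-membered ring of compound 1. The same position also shows its first step beyond the scatter: thiophen-2-yl in place of 3,5-dimethylphenyl gives a 2.1-fold higher number from compound 2 to compound 4 (0.33 log units; beyond the scatter), a modest gap that separates only the two ends of the series, as each compound in the ranking stays within the scatter of the next. Nothing available accounts for this gap or links it to any property of the two groups.

As far as these compounds go, all four compounds carry an aromatic ring at this position, so it remains open whether an amine, a carboxylic acid or a longer alkyl chain there would keep the number in this assay within this narrow range. From the compounds shown here alone, it is equally open whether furan-2-yl or thiophen-3-yl would stand level with thiophen-2-yl.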